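The source may report more compounds than this note shows. Statements on the series, on what has been measured and on what is new or still open speak of the compounds shown alone.

Measured so far:
- Compound 1, `Cn1c(=O)c2nc(-c3ccccc3[N+](=O)[O-])[nH]c2n(C)c1=O`: 80 nM
- Compound 2, `CCc1ccc(-c2nc3c(=O)n(C)c(=O)n(C)c3[nH]2)cc1`: 0.8 nM
- Compound 3, `Cn1c(=O)[nH]c2[nH]c(-c3ccccc3)nc2c1=O`: 2.5 nM

In an assay for binding affinity to adenosine receptor A1 (Bos taurus) (on this read-out lower numbers stand for stronger inhibition and higher numbers for weaker inhibition), compound 2 gives 0.8 nM, the lowest of the three numbers and thus the strongest binder shown. Its nearest neighbour is compound 3, which gives 2.5 nM in this assay, a gap beyond the scatter. Compound 1 gives 80 nM in this assay, the furthest from compound 2.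

Compound 4, `Cn1c(=O)c2nc(-c3ccc([N+](=O)[O-])cc3)[nH]c2n(C)c1=O`, has not yet been measured in this assay. It differs from compound 2 in one place: nitro in place of ethyl on an aromatic carbon. Among the compounds with values here, no measured pair in this set shows the same exchange, so the size of the step rests on judgement alone. Compound 1, which also carries a nitro group on its phenyl ring, sits far above compound 2, which suggests the nitro group is unlikely to help. The step from compound 2 to compound 4 in this assay is expected to weaken binding, a 13-fold higher number from compound 2 to compound 4 (1.10 log units; beyond the scatter), beyond the scatter. Compound 4 is thus estimated at 10 nM in this assay, with a plausible range from 2 nM to 60 nM.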

Compound 4, half-maximal inhibitory concentration: 8 nM
The estimate for compound 4 lay 1.3-fold (0.10 log units) above the measured number; the range from low to high includes it.
By their numbers in this assay, from the lowest: compound 2; then compound 3; then compound 4; then compound 1.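

In this assay, nitro in place of ethyl on an aromatic carbon, para to a large group, gives a measurable loss of binding: a 10-fold higher number from compound 2 to compound 4 (1.00 log units; beyond the scatter). Within the data shown here, this is the only measured step at this place, and it shows that the exchange weakens binding without abolishing it, since compound 4 still gives 8 nM. Nothing shown here accounts for the size of this step.

With only ethyl and nitro compared at this place, the compounds shown leave open how an amine, a carboxylic acid or a longer chain would read out there. They also leave open whether the same exchange would give a step of similar size on the core of compound 3.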